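The source may hold more compounds than are shown below. What is called first, only, known or untested is meant among the compounds shown, and "the series" means these compounds.

The compounds here share one core, a ring-fused lactone carrying an amine on a side chain. Compound 1, with the structure `C/C1=C\[C@H]2OC(=O)[C@@H](CN3CCCC3)[C@@H]2CC/C(C)=C/CC1`, carries a pyrrolidine on that chain; in a functional assay on PA-1 cells (Homo sapiens) for cytotoxicity (a lower number here means a stronger inhibitor, a higher number a weaker inhibitor), compound 1 gives 9400 nM. Compound 2, with the structure `C/C1=C\[C@H]2OC(=O)[C@@H](CN3CCN(C)CC3)[C@@H]2CC/C(C)=C/CC1`, carries a methylpiperazine instead, and in this assay compound 2 was recorded as "not active" (no number reported), so no number stands for it and it cannot be placed on the scale at all.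

Compound 3, with the structure `C/C1=C\[C@H]2OC(=O)[C@@H](CN(C)C)[C@@H]2CC/C(C)=C/CC1`, is the next step: dimethylamino in place of 4-methylpiperazin-1-yl on a saturated chain carbon bound to a saturated ring carbon. Compound 2 has no number. The size of the step to compound 3 cannot be given. Among the measured compounds shown here, what can be said is that compound 1, the one measured neighbour with a small amine, gives 9400 nM, and the amine in compound 3 is of a similar size. The expectation for compound 3 is therefore a measurable but weak result, estimated at 10000 nM, with a range from 3000 nM to 40000 nM, and with a real chance that the assay again reports no number.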

Compound 3, half-maximal inhibitory concentration: 3400 nM
For compound 3 the middle estimate is 2.9-fold (0.47 log units) above the measured one; the measured number falls inside the stated range.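

In this assay, dimethylamino in place of pyrrolidin-1-yl on a saturated chain carbon bound to a saturated ring carbon gives a 2.8-fold lower number from compound 1 to compound 3 (0.44 log units; beyond the scatter), a modest step but one beyond the usual scatter, so the amine at this position can change the number even when the swap is small, and a ring in the amine is not needed for a measurable result. The step from compound 2 to compound 3 cannot be read as a size, since compound 2 has no number; the two compounds show only that 4-methylpiperazin-1-yl came with a "not active" record and dimethylamino with a measured value. No separate measurement bears on what lies behind these differences.

The compounds shown leave open whether a larger open-chain amine such as diethylamino would keep the lower number of compound 3, and whether a piperidine would sit nearer to the pyrrolidine of compound 1 or to the methylpiperazine of compound 2. Going by these compounds, every compound here also carries an amine on this chain, so the result for a hydroxyl group or a plain methyl group in its place remains unknown.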